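Two Limits and a Fluorophenyl Sulfonamide

The compounds below may be only part of what the source reports. "The series", "measured", "known", "first", "only" and "open" are said of these compounds alone.

Compound 1 `COc1ccc(S(=O)(=O)Nc2ccc(-c3nc4ccccc4o3)cc2)cc1` is the reference point of this small set. In an assay on isolated protein for inhibition of malate dehydrogenase, mitochondrial (Sus scrofa), with stated times of 45 min and 30 min (on this read-out higher numbers stand for weaker inhibition and lower numbers for stronger inhibition), compound 1 gives > 63000 nM, which is a limit of the assay rather than a number. Its neighbour compound 2 `O=S(=O)(Nc1ccc(-c2nc3ccccc3o2)cc1)c1ccc(C(F)(F)F)cc1` carries trifluoromethyl in place of methoxy on an aromatic carbon. In this assay compound 2 gives > 63000 nM, again a limit. Going by the values given here, the step that the two limits leave unreadable from compound 1 to compound 2 therefore cannot be read, and the only evidence available is the limit of > 63000 nM in this assay, at which 2 of the 2 values shown sit. Compound 3 `O=S(=O)(Nc1ccc(-c2nc3ccccc3o2)cc1)c1ccccc1F` has not yet been measured in this assay. It differs from compound 1 by 2-fluorophenyl in place of 4-methoxyphenyl on a sulfonyl sulfur. Among the compounds with values here, no measured step resembles this change, and the one step that might have guided it is hidden by the two limits; the data give no sign that either replacement on the sulfonyl sulfur brings the series into the readable range. Compound 3 is therefore expected to sit at the limit as well, with a number no higher from compound 1 to compound 3 (the limit leaves the size open) meaning no step beyond the scatter. The estimate for compound 3 in this assay is 63000 nM, with a range from 20000 nM to 200000 nM.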

Compound 3, half-maximal inhibitory concentration: > 63000 nM
Compound 3 was reported as a limit (the forecaster's own chance of this, stated with the estimate: 80%); the middle value sits exactly at the limit.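

Compound 3, like compound 1, is reported only as a limit in this assay, so no step between these two compounds can be read, and the sole evidence stays this: the limit of > 63000 nM in this assay, at which 3 of the 3 values shown sit.

The compounds shown leave open how strongly any of the three inhibits, and whether any group on the sulfonyl sulfur gives a readable value.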